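Notes on the amide exchange from compound 2

The compounds below may be only part of what the source reports. "The series", "measured", "known", "first", "only" and "open" are said of these compounds alone.

Measured in a functional assay on KBVIN cells (Homo sapiens) for antiproliferative activity, read by sulforhodamine B assay, with a stated time of 3 days; a lower number here means a stronger inhibitor of growth, a higher number a weaker inhibitor of growth:
compound 1 `COc1ccc(N2CCN(C)CC2)cc1Nc1ncc(F)c(Nc2ccc(F)cc2)n1`: 910 nM
compound 2 `COc1ccc(NC(=O)c2cccc(Nc3ncc(F)c(Nc4ccc(F)cc4)n3)c2)cc1`: 15700 nM

Of these two compounds, compound 2 has the higher number at 15700 nM and compound 1 the lower at 910 nM, a gap beyond the usual scatter.

Compound 3 `O=C(Nc1cc(Cl)cc(Cl)c1)c1cccc(Nc2ncc(F)c(Nc3ccc(F)cc3)n2)c1` has 3,5-dichlorophenyl in place of 4-methoxyphenyl on an amide-type nitrogen. Within the data shown here, no measured pair shows a change at this place, so the expectation is weakly supported. Compound 2 holds the higher of the two numbers at 15700 nM, so a lower number seems the likelier direction in this assay. The estimate is a modest step, a 2.2-fold lower number from compound 2 to compound 3 (0.35 log units; beyond the scatter), close to the edge of the scatter. Compound 3 is expected at 7000 nM (estimated range 2000 nM to 20000 nM).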

Compound 3, concentration for 50% growth inhibition: 20700 nM
Estimate against measurement, compound 3: 3.0-fold (0.47 log units) below, outside the stated range (above it).
By their numbers in this assay, from the lowest: compound 1; then compounds 2 and 3 (each within the scatter of the next).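

Among these compounds, on the amide-type nitrogen, 3,5-dichlorophenyl in place of 4-methoxyphenyl gives the first reading of a change at this place: in this assay, the exchange produces a 1.3-fold higher number from compound 2 to compound 3 (0.12 log units; within the scatter). The two groups have the same heavy-atom count and differ in their atoms and in the hydrogen-bond acceptor count, yet this assay does not separate them, so this one exchange of aryl groups leaves the number where it was within the scatter. No measurement is at hand that bears on why the two groups read alike.

Open, on these data alone, is whether this place responds at all to a group of another kind, such as a plain alkyl chain in place of the aryl ring, or an aryl ring carrying an amine or a carboxylic acid. Two aryl groups also cannot show whether the amide linkage itself matters to the number.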